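The source may report more compounds than this note shows. Statements on the series, on what has been measured and on what is new or still open speak of the compounds shown alone.

Compound 1 `O=C1O[C@H]([C@@H](O)Cn2cc(CNS(=O)(=O)c3ccc(F)cc3)nn2)C(OCc2ccccc2)=C1OCc1ccccc1` gives 30 nM in an ADME assay on HFF cells (Homo sapiens) for cytotoxicity, read by MTT assay, with a stated time of 72 h; a higher number here means a weaker inhibitor, a lower number a stronger inhibitor.
Compound 2 `COc1ccccc1-c1cn(C/C=C2\OC(=O)C(OCc3ccccc3)=C2OCc2ccccc2)nn1` gives > 100000 nM, which is a limit of the assay rather than a number.
Compound 3 `O=C1O/C(=C\Cn2cc(-c3cc(C(F)(F)F)cc(C(F)(F)F)c3)nn2)C(OCc2ccccc2)=C1OCc1ccccc1` gives > 100000 nM, again a limit of the assay rather than a number.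

Going by the values given here, compound 1 thus holds the only numerical value of the three; compounds 2 and 3 sit at the limit of > 100000 nM in this assay, at which 2 of the 3 values shown sit. Compound 4 `O=C1O[C@H]([C@@H](O)Cn2cc(CCCCl)nn2)C(OCc2ccccc2)=C1OCc1ccccc1` keeps the core of compound 1 and differs from it by 2-chloroethyl in place of ((4-fluorophenyl)sulfonyl)amino on a saturated chain carbon bound to an aromatic carbon. Among the compounds with values here, no step between two measured compounds is available to gauge such a change, and the two limits give no direction for it. Compound 4 is expected to be a somewhat weaker inhibitor, the expected step being a 10-fold higher number from compound 1 to compound 4 (1.00 log units; beyond the scatter), though a step no larger than the scatter is also plausible. In this assay compound 4 is estimated at 300 nM, within a range of 30 nM to 10000 nM.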

Compound 4, half-maximal inhibitory concentration: 27100 nM
Compound 4: the middle estimate sits 90-fold (1.96 log units) below what was measured; the whole stated range lies below it.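

In this assay the place on a saturated chain carbon bound to an aromatic carbon proves sensitive: 2-chloroethyl in place of ((4-fluorophenyl)sulfonyl)amino gives a 900-fold higher number from compound 1 to compound 4 (2.96 log units; beyond the scatter) on the shared core, a large step beyond the scatter. Going by these compounds alone, this is the first change whose size can be read, as compound 2 and compound 3 each give a limit of the assay and not a number: the limit of > 100000 nM in this assay, at which 2 of the 4 values shown sit.

Which part of the departing group carries the difference stays open. From the compounds shown here alone, whether an amine, an amide or a longer chain ending in a phenyl ring at this place would give a number nearer that of compound 1 also stays open.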